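The compounds below may be only part of what the source reports. "The series", "measured", "known", "first", "only" and "open" are said of these compounds alone.

The three measured compounds, with their values in a physicochemical assay for lipophilicity, at pH 7.4; a higher number here means a more lipophilic compound, a lower number a more polar compound:

compound 1, `CN(Cc1ccc2nccn2c1)c1nnc(-c2ccc(-c3ccccc3C#N)cc2)o1`, 3.6;
compound 2, `Cc1ccccc1-c1ccc(-c2nnc(N(C)Cc3ccc4nccn4c3)o2)cc1`, 4.7;
compound 3, `Cc1cc(-c2c(C)nn(C)c2C)ccc1-c1nnc(N(C)Cc2ccc3nccn3c2)o1`, 3.7.

Compound 2 has the highest number of the three in this assay. Compound 1 differs from it in a single place: cyano in place of methyl on an aromatic carbon. This change gave a number 1.10 log units lower from compound 2 to compound 1 (beyond the scatter). Compound 3 stands second of the three; its number lies within the scatter of compound 1 and beyond the scatter below compound 2. The difference between the core of compound 3 and the core of compound 2 is not broken down here.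

Compound 4, `Cc1nn(C)c(C)c1-c1ccc(-c2nnc(N(C)Cc3ccc4nccn4c3)o2)c(C#N)c1`, is not yet measured in this assay. It differs from compound 3 by the same kind of change: cyano in place of methyl on an aromatic carbon. The place is not the same word for word as in the pair already measured: in compound 4 the aromatic carbon is also meta to a 1,3,5-trimethyl-1H-pyrazol-4-yl group, which the corresponding place in compound 1 does not carry. The change has been measured only once among these compounds, so the expectation rests on that single step together with the value of compound 3. Compound 4 is expected to show a step of a number 1.10 log units lower from compound 3 to compound 4 (beyond the scatter), about as large as the earlier step of a number 1.10 log units lower from compound 2 to compound 1 (beyond the scatter). Compound 4 is therefore estimated at 2.6, within a range from 2.1 to 3.1.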

Compound 4, distribution coefficient: 2.9
Compound 4: the middle estimate sits 0.30 log units below what was measured, and the stated range covers the measured number.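

Carried from the core of compound 2 to the core of compound 3, the replacement of methyl by cyano on an aromatic carbon again lowered the number in this assay, giving a number 0.80 log units lower from compound 3 to compound 4 (beyond the scatter), in the same direction as the earlier a number 1.10 log units lower from compound 2 to compound 1 (beyond the scatter), so across these two pairs the direction of the change held and both steps lie beyond the scatter. Among these compounds, this does not show that the step has a fixed size or that it would carry to any other core: there are only two pairs, each step rests on a single comparison, and the two sizes alone cannot say whether the 1,3,5-trimethyl-1H-pyrazol-4-yl group has any part in how they compare. Nothing given here bears on what lies behind the size of either step.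

The compounds shown leave open how a methoxy group, a chlorine atom or a carboxylic acid on that same aromatic carbon would read in this assay. They also leave open whether the step would keep its direction on a core carrying an amine or a longer chain in place of the 1,3,5-trimethyl-1H-pyrazol-4-yl group.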